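The compounds below may be only part of what the source reports. "The series", "measured", "known", "first", "only" and "open" are said of these compounds alone.

In a functional assay on HT-29 cells (Homo sapiens) for cytotoxicity, read by MTT assay, with a stated time of 72 h (on this read-out lower numbers stand for stronger inhibition and higher numbers for weaker inhibition), compound 1 `COc1cc2c(Oc3ccc(NC(=O)c4nnn(-c5ccc(F)cc5)c4C(F)(F)F)cc3F)ccnc2cc1OCCCN1CCCC1` gives 120 nM, and compound 2 `COc1cc2c(Oc3ccc(NC(=O)c4nnn(-c5ccc(F)cc5)c4C(F)(F)F)cc3F)ccnc2cc1OCCCN1CCCCC1` gives 150 nM. Within the data shown here, the only step among the measured compounds is a 1.3-fold higher number from compound 1 to compound 2 (0.10 log units; within the scatter). Compound 2 thus stands highest of the two numbers shown, with compound 1 the nearest neighbour, and the gap between them within the scatter.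

Compound 3 `COc1cc2c(Oc3ccc(NC(=O)c4nnn(-c5ccc(F)c(F)c5)c4C(F)(F)F)cc3F)ccnc2cc1OCCCN1CCCCC1` has not yet been measured. It differs from compound 2 by fluoro in place of hydrogen on an aromatic carbon. Among the measured compounds shown here, no measured step touches this part of the molecule: the step from compound 1 to compound 2 concerns the amine ring at the end of the chain and leaves the 4-fluorophenyl group untouched. The two numbers at hand therefore give no ground for a change in either direction, and the expectation for this assay rests on compound 2 alone, widened for the unknown effect of the new substituent. The estimate for compound 3 is 150 nM, with a range from 70 nM to 320 nM. The step this implies is expected to be no change at the digits printed from compound 2 to compound 3 (within the scatter), none beyond the scatter.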

Compound 3, half-maximal inhibitory concentration: 180 nM
Beside the measured number, compound 3's estimate is 1.2-fold (0.08 log units) below it; low and high end bracket the measured number.
By their numbers in this assay, from the lowest: compounds 1, 2 and 3 (each within the scatter of the next).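

In this assay, fluoro in place of hydrogen on an aromatic carbon, ortho to a fluoro group, turns 4-fluorophenyl into 3,4-difluorophenyl and gives a 1.2-fold higher number from compound 2 to compound 3 (0.08 log units; within the scatter). Among these compounds, this is the first reading on this aromatic ring, which the earlier step, confined to the amine ring at the end of the chain, left untouched, and it shows that a further fluoro at this position keeps the number within the scatter when the chain ends in piperidin-1-yl. No available information accounts for this result or bears on it.

From the compounds shown here alone, a single fluorine atom is a small probe, so it remains open whether a chloro, methoxy, nitrile or dimethylamino group at the same carbon would also stay within the scatter or would move the number beyond it. Going by these compounds, it is equally open whether the same fluoro would give a step of similar size with pyrrolidin-1-yl at the end of the chain, and what an unsubstituted phenyl in place of the 4-fluorophenyl group would give.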